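Hydrogen for chloro: from compound 2 to compound 3

The source may hold more compounds than are shown below. What is called first, only, known or untested is meant among the compounds shown, and "the series" means these compounds.

Measured in a physicochemical assay for solubility, read by nephelometry, measured as kinetic solubility; on this read-out higher numbers stand for higher solubility and lower numbers for lower solubility:
Compound 1 (`CCC/N=C1\S/C(=C\c2ccc(C(=O)O)cc2)C(=O)N1c1ccccc1C`): 163000 nM
Compound 2 (`CCC/N=C1\S/C(=C\c2ccc(C(=O)OC)c(Cl)c2)C(=O)N1c1ccccc1C`): 39000 nM

Compound 2, at 39000 nM, stands lowest of the two, and compound 1 lies higher at 163000 nM, a gap beyond the scatter. Compound 3 (`CCC/N=C1\S/C(=C\c2ccc(C(=O)OC)cc2)C(=O)N1c1ccccc1C`) has hydrogen in place of chloro on an aromatic carbon, ortho to a methoxycarbonyl group (hydrogen in place of chloro on an aromatic carbon). For the measured compounds named here, no measured pair shows this change alone, so only a modest rise in this assay is expected, possibly within the scatter. The expected change is a 1.5-fold higher number from compound 2 to compound 3 (0.19 log units; within the scatter). For compound 3, the estimated value is 60000 nM, with an expected range from 25000 nM to 140000 nM.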

Compound 3, solubility: 28000 nM
Compound 3: the middle estimate sits 2.1-fold (0.33 log units) above what was measured; the measured number falls inside the stated range.
By their numbers in this assay, from the lowest: compounds 3 and 2 (each within the scatter of the next); then compound 1.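

In this assay chloro and hydrogen on this aromatic carbon, ortho to a methoxycarbonyl group, show a 1.4-fold lower number from compound 2 to compound 3 (0.14 log units; within the scatter) and so cannot be told apart at this position. With chloro absent, the change at the other end of the molecule, methyl in place of hydrogen on an oxygen next to a carbonyl group, now stands alone and gives a 5.8-fold lower number from compound 1 to compound 3 (0.77 log units; beyond the scatter) as its size in this read-out. Nothing available accounts for either step.

The compounds shown leave open what fluoro or a nitrile on the same aromatic carbon would give. They also leave open what a longer chain in place of that methyl would give.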